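Replacing 4-nitrophenyl with phenethyl: an expected cytotoxicity outcome

The source may hold more compounds than are shown below. What is called first, only, known or untested is meant among the compounds shown, and "the series" means these compounds.

Compound 1 `O=C1c2ccccc2N(Cc2ccc([N+](=O)[O-])cc2)S(=O)(=O)N1Cc1ccccc1` was measured in a functional assay on MRC5 cells (Homo sapiens); a lower number here means that less compound is tolerated, a higher number that more compound is tolerated. In this assay compound 1 gives only a limit, > 59000 nM, so no exact number is known for it. Compound 2 `O=S1(=O)N=C(OCc2ccccc2-c2ccccc2)c2ccccc2N1Cc1ccccc1-c1ccccc1` shares no single-point difference with compound 1. In this assay compound 2 gives 47000 nM. The measured evidence amounts to the limit of > 59000 nM in this assay, at which 1 of the 2 values shown sits. The change from compound 1 to compound 3 `O=C1c2ccccc2N(CCCc2ccccc2)S(=O)(=O)N1Cc1ccccc1` is phenethyl in place of 4-nitrophenyl on a saturated chain carbon bound to a sulfonamide nitrogen in a ring. Within the data shown here, with no measured step to guide the size, the step of an at least 1.0-fold lower number from compound 1 to compound 3 (0.03 log units; that floor lies within the scatter) is expected to stay within the scatter, in no clear direction. For compound 3 the estimate in this assay is 55000 nM, within a range from 25000 nM to 120000 nM.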

Compound 3, half-maximal cytotoxic concentration: > 57000 nM
Compound 3: only a limit was reported; the forecaster's own chance of this, stated with the estimate: 60%; middle value at least 1.0-fold (0.01 log units) away from the limit.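

Among these compounds, compound 1 and compound 3 are both reported only as limits in this assay, and no step between them can be read. The compounds shown leave open whether phenethyl in place of 4-nitrophenyl changes the half-maximal cytotoxic concentration at all.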